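Shortening the Alkyl Chain of an Iminosugar Glucosidase Inhibitor

A few compounds are considered here, and "the series" means these few. Any claim that something is new, unique, unknown or untested is made for them only; others in the source may bear on it.

Compound 1, `CCCCCCCCC[C@@]1(CO)NC[C@H](O)[C@H]1O`: 960 nM in an assay on isolated protein for inhibition of lysosomal alpha-glucosidase (Rattus norvegicus), read by colorimetric assay; a lower number here means a stronger inhibitor, a higher number a weaker inhibitor
Compound 2, `CCCCCCCCC[C@]1(CO)NC[C@@H](O)[C@@H]1O`: 66000 nM

Compound 1 stands as the lower of the two numbers in this assay. For the measured compounds named here, the only measured step from it, a 69-fold higher number from compound 1 to compound 2 (1.84 log units; beyond the scatter), rests on the fact that compounds 1 and 2 differ only in the configuration as drawn and touches nothing about the alkyl chain. Compound 3, `CCCC[C@@]1(CO)NC[C@H](O)[C@H]1O`, differs from compound 1 by hydrogen in place of pentyl on a saturated chain carbon, four bonds along the chain from a saturated ring carbon. Going by the values given here, no measured step bears on a change of chain length, so the mirror-image step gives no guide to its size or direction. Compound 3 is nevertheless expected to give a somewhat higher number, roughly a 5.2-fold higher number from compound 1 to compound 3 (0.72 log units; beyond the scatter). Compound 3 is estimated at 5000 nM, within a range of 1000 nM to 30000 nM.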

Compound 3, half-maximal inhibitory concentration: 220 nM
Compound 3: the middle estimate sits 23-fold (1.36 log units) above what was measured; the whole stated range lies above it.
By their numbers in this assay, from the lowest: compound 3; then compound 1; then compound 2.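

At this saturated chain carbon, four bonds along the chain from a saturated ring carbon, hydrogen in place of pentyl gives, in this assay, a 4.4-fold lower number from compound 1 to compound 3 (0.64 log units; beyond the scatter). The shorter chain of compound 3 thus gives a stronger inhibitor than compound 1, so the full chain of compound 1 is not required for inhibition in this series. No measured property accounts for this step. As far as these compounds go, it remains open whether a still shorter chain or a chain longer than that of compound 1 would lower the number further, and how a carboxylic acid on the chain would read.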